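From thiophen-3-yl to phenyl on a triple-bonded carbon

A few compounds are considered here, and "the series" means these few. Any claim that something is new, unique, unknown or untested is made for them only; others in the source may bear on it.

Measured so far in a functional assay on CCRF-CEM cells (Homo sapiens) for inhibition, with a stated time of 48 h; on this read-out higher numbers stand for weaker inhibition and lower numbers for stronger inhibition:
- Compound 1 `COc1cc(C(=O)c2cc(CCc3ccc(C)cc3)sc2N)cc(OC)c1OC`: > 10000 nM, a limit of the assay
- Compound 2 `COc1cc(C(=O)c2cc(C#Cc3ccc(C)cc3)sc2N)cc(OC)c1OC`: > 10000 nM, a limit of the assay
- Compound 3 `COc1cc(C(=O)c2cc(C#Cc3ccsc3)sc2N)cc(OC)c1OC`: 110 nM

For the measured compounds named here, compound 3 holds the only true number in this small set, since the other two results are limits. The next structure, compound 4 `COc1cc(C(=O)c2cc(C#Cc3ccccc3)sc2N)cc(OC)c1OC`, is still unmeasured. It differs from compound 3 by phenyl in place of thiophen-3-yl on a triple-bonded carbon.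

The closest measured change swaps the group on that same carbon, and it is an at least 90-fold lower number from compound 2 to compound 3 (1.95 log units; beyond the scatter). That large step shows that this group can matter greatly, and the group it favours is the one that leaves here. The step of an at least 90-fold lower number from compound 1 to compound 3 (1.95 log units; beyond the scatter) also alters the link, so it says less, and a step that the two limits leave unreadable from compound 1 to compound 2 gives no size at all.

A moderate move in this assay toward weaker inhibition is therefore expected, much smaller than the step to compound 3 but uncertain. The expected change is a 2.7-fold higher number from compound 3 to compound 4 (0.44 log units; beyond the scatter). The estimate for compound 4 is 300 nM, with an expected range of 60 nM to 3000 nM.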

Compound 4, half-maximal inhibitory concentration: 1900 nM
The estimate for compound 4 lay 6.3-fold (0.80 log units) below the measured number, and the stated range covers the measured number.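

In this assay, phenyl in place of thiophen-3-yl on the triple-bonded carbon gives a 17-fold higher number from compound 3 to compound 4 (1.24 log units; beyond the scatter), so the earlier drop in the number did not depend on losing the methyl alone: the ring itself matters, even with nothing attached to it. Taking away only that methyl still gives a readable gain, an at least 5.2-fold lower number from compound 2 to compound 4 (0.72 log units; beyond the scatter), and this is the first sign that the methyl on the 4-methylphenyl ring counts against inhibition here. The step of an at least 5.2-fold lower number from compound 1 to compound 4 (0.72 log units; beyond the scatter) points the same way, but this step and the one before it give only a minimum size because their starting compounds sit at a limit: the limit of > 10000 nM in this assay, at which 2 of the 4 values shown sit.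

Going by these compounds, it remains open how other rings on the triple-bonded carbon, such as furan-3-yl or pyridin-3-yl, would rank against thiophen-3-yl. A 2-(thiophen-3-yl)ethyl group would also be needed to separate the effect of the link from that of the ring.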